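A few compounds are considered here, and "the series" means these few. Any claim that something is new, unique, unknown or untested is made for them only; others in the source may bear on it.

Measured compounds:
compound 1, `O=c1c(-c2ccc(O)cc2)coc2cc(OCCCCBr)ccc12` — 55.3%
compound 2, `O=c1c(-c2ccc(O)cc2)coc2cc(OCCC3OCCCO3)ccc12` — 57.6%
compound 3, `O=c1c(-c2ccc(O)cc2)coc2cc(OCCCBr)ccc12` — 67.7%

All three share one core and differ only in the chain on the aromatic oxygen. In a functional assay on mitochondria (Cricetulus griseus) for inhibition of Monoamine oxidase (Homo sapiens), tested at 0.9 uM (a higher number here means a stronger effect of the compound at the concentration tested, a lower number a weaker effect), compound 3 gives the highest of the three numbers: the steps of a number 12.4 percentage points higher from compound 1 to compound 3 (beyond the scatter) and a number 10.1 percentage points higher from compound 2 to compound 3 (beyond the scatter) are both beyond the scatter, while a number 2.3 percentage points higher from compound 1 to compound 2 (within the scatter) is within it.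

Compound 4, `O=c1c(-c2ccc(O)cc2)coc2cc(OCC(O)CO)ccc12`, is not yet measured. Its change from compound 3 is 1,2-dihydroxyethyl in place of 2-bromoethyl on a saturated chain carbon bound to an oxygen on an aromatic ring; cut one bond further out, 3-bromopropoxy becomes 2,3-dihydroxypropoxy, so the bromine leaves and two hydrogen-bond donors enter on the chain. Going by the values given here, no measured step introduces hydroxyl groups, so the bearing is indirect. The nearest comparison is a number 10.1 percentage points higher from compound 2 to compound 3 (beyond the scatter), where a chain bearing two oxygens gave way to a bromine-bearing chain and the number rose modestly; compound 4 runs the other way, oxygen in place of bromine. a number 2.3 percentage points higher from compound 1 to compound 2 (within the scatter), oxygens in place of bromine at a longer reach, stayed within the scatter. A modest fall in this assay, or none beyond the scatter, is therefore expected for compound 4, with the estimated step being a number 15.7 percentage points lower from compound 3 to compound 4 (beyond the scatter). Compound 4 is estimated at 52%, with a range from 36% to 66%.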

Compound 4, a percentage reported as inhibition, at one concentration (the size of the read-out at that concentration, not a potency): 63.8%
Estimate against measurement, compound 4: 11.8 percentage points below; the range from low to high includes it.
By their numbers in this assay, from the lowest: compounds 1, 2, 4 and 3 (each within the scatter of the next, the first and the last beyond it).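

In this assay, the change from 3-bromopropoxy to 2,3-dihydroxypropoxy gives a number 3.9 percentage points lower from compound 3 to compound 4 (within the scatter), so at this position the bromine can leave and hydroxyl groups can enter on the chain without a shift beyond the scatter. The two other new steps, a number 6.2 percentage points higher from compound 2 to compound 4 (within the scatter) and a number 8.5 percentage points higher from compound 1 to compound 4 (within the scatter), are also within the scatter, so 2,3-dihydroxypropoxy cannot be separated from any of the three earlier chains, and the modest gaps that set compound 3 apart from compound 1 and compound 2 do not divide the series into two clear levels. No measurement at hand explains why this position accepts both the bromine-bearing chains and the hydroxyl-bearing chain.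

Still open, going by these compounds, is how a chain ending in an amine or a carboxylic acid would read, and whether a 3-hydroxypropoxy chain, with a single hydroxyl, would stay within the scatter of compound 4. The read-out also comes from one concentration, so it leaves open whether compounds that cannot be separated here would also match in potency.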